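This account rests on a few compounds, and the source may have more. Where it says the series, first, only, none or still open, it means among the compounds named here.

Measured so far:
Compound 1, `CC/C(=C(/c1ccc(/C=C/C(=O)O)cc1)c1cc2ccccc2[nH]1)c1ccc(OC)cc1`, gives 61 nM in a functional assay on MCF7 cells (Homo sapiens) for inhibition; a lower number here means a stronger inhibitor, a higher number a weaker inhibitor.
Compound 2, `CC/C(=C(/c1ccc(/C=C/C(=O)O)cc1)c1cc2ccccc2[nH]1)c1ccc(Cl)cc1C#N`, gives 14 nM in this assay.

Going by the values given here, compound 2 holds the lower of the two numbers; the single measured step, a 4.4-fold lower number from compound 1 to compound 2 (0.64 log units; beyond the scatter), separates it from compound 1. Compound 3, `CC/C(=C(/c1ccc(/C=C/C(=O)O)cc1)c1cc2ccccc2[nH]1)c1ccc(Cl)cc1C(F)(F)F`, differs from compound 2 by trifluoromethyl in place of cyano on an aromatic carbon. Among the compounds with values here, no measured step covers this exchange. Within the data shown here, the one step in hand, a 4.4-fold lower number from compound 1 to compound 2 (0.64 log units; beyond the scatter), replaced the whole ring at that position rather than one group on it, so it says little about trading cyano for trifluoromethyl. With nothing pointing either way, the expectation is a change of no more than the usual scatter in this assay. The estimated step of a 1.4-fold higher number from compound 2 to compound 3 (0.15 log units; within the scatter) is therefore small. Compound 3 is expected to give about 20 nM, within a range from 7 nM to 60 nM.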

Compound 3, half-maximal inhibitory concentration: 4 nM
For compound 3 the middle estimate is 5.0-fold (0.70 log units) above the measured one; measured number below the stated range.
By their numbers in this assay, from the lowest: compound 3; then compound 2; then compound 1.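

With the rest of the molecule unchanged, exchanging cyano for trifluoromethyl on this aromatic carbon gives a 3.5-fold lower number from compound 2 to compound 3 (0.54 log units; beyond the scatter) in this assay. A single group on this ring can therefore move the number beyond the scatter, which the earlier step could not show, as it replaced the whole ring. Replacing 4-methoxyphenyl with 4-chloro-2-(trifluoromethyl)phenyl now gives a 15-fold lower number from compound 1 to compound 3 (1.18 log units; beyond the scatter), a large step, but no measurement offered here explains the difference between these groups.

The chloro group never changes on its own among these three compounds, so its separate share in these numbers remains open. Also open, from the compounds shown here alone, is how a smaller or different group on the same aromatic carbon, such as a methyl, an amine or a carboxylic acid, would compare with trifluoromethyl.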